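From dichlorophenyl to bromophenyl on a shared core

The compounds below may be only part of what the source reports. "The series", "measured", "known", "first", "only" and "open" are said of these compounds alone.

Compounds tested so far in a functional assay on PC-3 cells (Homo sapiens) for cytotoxicity, read by MTT assay, with a stated time of 72 h (on this read-out lower numbers stand for stronger inhibition and higher numbers for weaker inhibition), and their results:

- compound 1 `CNC(=O)c1cc(Oc2ccc(C3=NNC(c4ccc(F)cc4Cl)C3)cc2)ccn1` gives 24300 nM
- compound 2 `CNC(=O)c1cc(Oc2ccc(C3=NNC(c4cccc([N+](=O)[O-])c4)C3)cc2)ccn1` is recorded as "not determined" (no result reported)
- compound 3 `CNC(=O)c1cc(Oc2ccc(C3=NNC(c4ccc(Cl)c(Cl)c4)C3)cc2)ccn1` gives 36200 nM

Going by the values given here, only two numbers are available, and they lie within the scatter of each other, so compound 3 stands level with compound 1 on this evidence. Compound 4 `CNC(=O)c1cc(Oc2ccc(C3=NNC(c4ccc(Br)cc4)C3)cc2)ccn1` awaits measurement. It carries 4-bromophenyl in place of 3,4-dichlorophenyl on a saturated ring carbon, and the difference from compound 3 counts as 4-bromophenyl in place of 3,4-dichlorophenyl on a saturated ring carbon with the rest of the structure unchanged.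

Among the compounds with values here, one measured step bears on this change. In a 1.5-fold higher number from compound 1 to compound 3 (0.17 log units; within the scatter) one halogen-bearing phenyl group replaced another at the same saturated ring carbon, and that step stayed within the scatter. Within the data shown here, compound 2 offers no number for comparison, and no bromophenyl compound has yet been tested, so the evidence is thin. The expected change is a 1.2-fold lower number from compound 3 to compound 4 (0.08 log units; within the scatter) and no shift beyond the scatter is anticipated in either direction in this assay on this basis. For compound 4 the estimated value is 30000 nM with an expected range from 13000 nM to 70000 nM in this assay.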

Compound 4, half-maximal inhibitory concentration: > 50000 nM
Compound 4 gave a limit, no number; the forecaster's own chance of this, stated with the estimate: 10%; at least 1.6-fold (0.22 log units) between middle value and limit.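

In this assay compound 4 gives a limit and not a number: the limit of > 50000 nM in this assay, at which 1 of the 4 values shown sits. Even so, this position now shows a step that clears the scatter, an at least 2.0-fold higher number from compound 1 to compound 4 (0.31 log units; beyond the scatter), when 4-bromophenyl replaces 2-chloro-4-fluorophenyl on the saturated ring carbon, whereas the earlier exchange of halogen-bearing phenyl groups, a 1.5-fold higher number from compound 1 to compound 3 (0.17 log units; within the scatter), did not separate the two compounds. The change from 3,4-dichlorophenyl is less firmly resolved: an at least 1.3-fold higher number from compound 3 to compound 4 (0.14 log units; that floor lies within the scatter) has a floor that does not by itself clear the scatter, so this comparison fixes neither the full size of the change nor a clear separation of the two compounds.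

Going by these compounds, how far the true result for compound 4 lies past its limit remains open, and so does the full size of both new steps. Also open is how an unsubstituted phenyl, a phenyl bearing an amine or one bearing a carboxylic acid would read at this saturated ring carbon on the shared core, and whether any such group would give a lower number than those of the halogen-bearing compounds shown here.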